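Dimethylamino in place of difluoromethoxy on an aromatic carbon

The compounds below may be only part of what the source reports. "The series", "measured", "known", "first", "only" and "open" are said of these compounds alone.

Among the measured compounds shown here, in a functional assay on MCF-10A cells (Homo sapiens) for antiproliferative activity, with a stated time of 48 h (a lower number here means that less compound is needed, a higher number that more compound is needed for the effect), compound 2 `COc1ccc2nc(C)cc(NCc3ccc(OC(F)F)cc3)c2c1` gives 14700 nM, the higher of the two numbers so far, while compound 1 `COc1ccc2nc(C)cc(NCc3ccc(C(C)(C)C)cc3)c2c1` gives 7000 nM. Compound 3 `COc1ccc2nc(C)cc(NCc3ccc(N(C)C)cc3)c2c1` carries dimethylamino in place of difluoromethoxy on an aromatic carbon, para to a large group: dimethylamino in place of difluoromethoxy on an aromatic carbon. For the measured compounds named here, the one measured step at this place is modest, a 2.1-fold higher number from compound 1 to compound 2 (0.32 log units; beyond the scatter), and it gives no direction for the new group. No step beyond the scatter is therefore expected in this assay. The estimated step is a 1.5-fold lower number from compound 2 to compound 3 (0.17 log units; within the scatter). For compound 3 the expected value is 10000 nM, with an estimated range of 4000 nM to 25000 nM.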

Compound 3, half-maximal effective concentration: 20000 nM
Compound 3: middle estimate off by 2.0-fold (0.30 log units), on the low side; measured number inside the range.
By their numbers in this assay, from the lowest: compound 1; then compounds 2 and 3 (each within the scatter of the next).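

In this assay the exchange of difluoromethoxy for dimethylamino stays within the scatter (a 1.4-fold higher number from compound 2 to compound 3 (0.13 log units; within the scatter)), so these two groups cannot be told apart at this position. Dimethylamino in place of tert-butyl gives a step beyond the scatter (a 2.9-fold higher number from compound 1 to compound 3 (0.46 log units; beyond the scatter)), and both replacements of tert-butyl now go the same way, leaving compound 1 with the lowest number of the three. Nothing given here accounts for this. Going by these compounds, whether a methyl group, a chlorine atom or a carboxylic acid at this place would stay with compound 2 and compound 3 or come closer to compound 1 remains open, as does whether any group here can go clearly lower than tert-butyl.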